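A few compounds are considered here, and "the series" means these few. Any claim that something is new, unique, unknown or untested is made for them only; others in the source may bear on it.

Compound 1 `COc1cc(-n2ncnc2-c2cccc([N+](=O)[O-])c2)cc(OC)c1OC`: > 10000 nM.
Compound 2 `COc1cc(-c2ncnn2-c2cccc(N)c2)cc(OC)c1OC`: > 10000 nM.

In a functional assay on Jurkat cells (Homo sapiens) for antiproliferative activity, read by MTT assay, with a stated time of 72 h (a lower number here means a stronger inhibitor, a higher number a weaker inhibitor), compound 2 reaches only the limit of the assay, > 10000 nM, and no number. Compound 1 also stands at a limit, > 10000 nM. Among the compounds with values here, both values sit on (the limit of > 10000 nM in this assay, at which 2 of the 2 values shown sit), so no step between measured compounds can be drawn. Compound 3 `COc1ccc(-n2ncnc2-c2cc(OC)c(OC)c(OC)c2)cc1` is not yet measured in this assay; it carries 4-methoxyphenyl in place of 3-aminophenyl on an aromatic nitrogen. With compound 2 at a limit, the expected step is a modest move toward stronger inhibition, though a further limit is nearly as likely. Compound 3 is expected to give 8000 nM, between 800 nM and 30000 nM. The step this estimate implies, an at least 1.2-fold lower number from compound 2 to compound 3 (0.09 log units; that floor lies within the scatter), is expected rather than measured.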

Compound 3, half-maximal inhibitory concentration: 93 nM
Beside the measured number, compound 3's estimate is 86-fold (1.93 log units) above it; measured number outside the range, below it.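

In this assay, the group on the aromatic nitrogen proves decisive: 4-methoxyphenyl in place of 3-aminophenyl gives an at least 100-fold lower number from compound 2 to compound 3 (2.03 log units; beyond the scatter). Within the data shown here, this is the first measured number, so this position can carry strong antiproliferative activity, which the earlier compounds could not show. The value of compound 2 is only a limit of the assay, so the true size of the step stays unknown: the limit of > 10000 nM in this assay, at which 2 of the 3 values shown sit.

Still open, on these data alone, is whether the step comes from gaining the methoxy group, losing the amine, or moving the substituent around the phenyl ring. A 3-methoxyphenyl or 4-aminophenyl group on the same nitrogen would separate these.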